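The source may hold more compounds than are shown below. What is called first, only, known or untested is meant among the compounds shown, and "the series" means these compounds.

Compound 1 `O=C(/C=C/c1ccccc1)c1ccc2occc2c1O` was tested in an assay on isolated protein for inhibition of lysosomal alpha-glucosidase (Rattus norvegicus), read by spectrophotometry, with a stated time of 5 min, tested at 25 ug/mL (on this read-out higher numbers stand for more inhibition at the one concentration tested (going by the name of the read-out) and lower numbers for less inhibition), where compound 1 gives 20.8%. On the three numbers at hand that puts compound 1 second highest. Compound 2 `O=C(/C=C/c1ccc(O)cc1)c1cc2ccoc2cc1O`, built on a differently arranged core, gives in this assay 8.77%, which sits below compound 1 by more than the scatter. Compound 3 `COc1ccc(/C=C/C(=O)c2ccc3occc3c2O)c(OC)c1OC` gives in this assay 67.3%, the top number and far above compound 1. Compound 4 `COc1ccc(/C=C/C(=O)c2ccc3occc3c2O)cc1` has not yet been measured; it differs from compound 1 by methoxy in place of hydrogen on an aromatic carbon. Because compound 3 reaches 67.3% carrying three methoxy groups, the expected step of a number 15.2 percentage points higher from compound 1 to compound 4 (beyond the scatter) is upward and beyond the scatter, though smaller than the gain shown by compound 3. Compound 4 is accordingly estimated at 36%, within 15% to 60%.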

Compound 4, a percentage reported as inhibition, at one concentration (the size of the read-out at that concentration, not a potency): 94.8%
Estimate against measurement, compound 4: 58.8 percentage points below, outside the stated range (above it).
By their numbers in this assay, from the lowest: compound 2; then compound 1; then compound 3; then compound 4.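

In this assay, a single methoxy in place of hydrogen on an aromatic carbon, para to a large group, gives a number 74 percentage points higher from compound 1 to compound 4 (beyond the scatter), so on this core one small change at this position is enough for a large step. The earlier compounds shown here offered no pair differing in one place, so no single change could be read from them. Nothing at hand accounts for the size of this step. Going by these compounds, it remains open whether an ethoxy, a chlorine or an amine at this position would give a similar step, and whether methoxy would do the same on the differently arranged core of compound 2.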